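The compounds below may be only part of what the source reports. "The series", "measured", "known", "first", "only" and "open" are said of these compounds alone.

Compound 1, `Cc1nc(C)c(-c2nn(-c3ccc(F)cc3)cc2C2CC(c3cc(Br)ccc3O)=NN2)s1`. In an ADME assay on THP-1 cells (Homo sapiens) for inhibition (on this read-out lower numbers stand for stronger inhibition of growth and higher numbers for weaker inhibition of growth), compound 1 gives > 30 ug/mL, which is a limit of the assay and not a number.
Compound 2, `Cc1nc(C)c(-c2nn(-c3ccc(F)cc3)cc2C2CC(c3cc(Cl)ccc3O)=NN2)s1`. In this assay compound 2 gives > 30 ug/mL, again a limit.
Compound 3, `Cc1nc(C)c(-c2nn(-c3ccc(F)cc3)cc2C2CC(c3cc(Cl)c(C)cc3O)=NN2)s1`. In this assay compound 3 gives > 30 ug/mL, also a limit.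

Compound 3 therefore stands exactly where the other two measured values stand, at the limit of > 30 ug/mL in this assay, at which 3 of the 3 values shown sit. None of the steps among these three compounds can be read: a step that the two limits leave unreadable from compound 1 to compound 2, a step that the two limits leave unreadable from compound 1 to compound 3 and a step that the two limits leave unreadable from compound 2 to compound 3 are each unreadable, since both ends of each are limits. The unmeasured compound 4, `Cc1nc(C)c(-c2nn(-c3ccc(F)cc3)cc2C2CC(c3c(O)cc(C)c(Cl)c3C)=NN2)s1`, differs from compound 3 by methyl in place of hydrogen on an aromatic carbon, a methyl in place of hydrogen on an aromatic carbon, ortho to a chloro group and meta to a hydroxy group. The closest measured parallel is a step that the two limits leave unreadable from compound 2 to compound 3, also methyl in place of hydrogen on an aromatic carbon, and it shows nothing more than that both compounds sit at the limit. Among the measured compounds shown here, no measured step therefore supplies a size or a direction for the change to compound 4. The step that the limit leaves unreadable from compound 3 to compound 4 is expected to lie within the scatter, with compound 4 most likely reported at the same limit. For compound 4 in this assay the estimate is 40 ug/mL, in a range from 15 ug/mL to 100 ug/mL.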

Compound 4, concentration for 50% growth inhibition: > 30 ug/mL
Compound 4: a limit, no number (the forecaster's own chance of this, stated with the estimate: 85%); the middle value does not contradict the limit.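

In this assay compound 4 gives > 30 ug/mL, a limit of the assay and not a number. The steps to compound 4 from compound 1, compound 2 and compound 3 therefore cannot be read: the limit of > 30 ug/mL in this assay, at which 4 of the 4 values shown sit.

The compounds shown leave open how strongly any of them inhibits growth, and whether the bromo, chloro or methyl changes shift this read-out at all.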